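The source may hold more compounds than are shown below. What is called first, only, known or untested is meant among the compounds shown, and "the series" means these compounds.

Measured compounds in a toxicity assay on Vero cells (Chlorocebus sabaeus) for cytotoxicity; a higher number here means that more compound is tolerated, a lower number that less compound is tolerated:
compound 1, `COc1nc(-c2ccc(Br)cc2)ccc1[C@@H](c1ccccc1)[C@@](O)(CCN(C)C)c1cccc2ccccc12`: > 50 ug/mL
compound 2, `COc1ncc(-c2ccccc2)cc1[C@@H](c1ccccc1)[C@@](O)(CCN(C)C)c1cc(F)ccc1F`: > 50 ug/mL
compound 3, `COc1ncc(-c2ccccc2)cc1[C@@H](c1ccccc1)[C@@](O)(CCN(C)C)c1cccc(F)c1F`: > 50 ug/mL

In this assay compound 1 gives > 50 ug/mL, which is a limit of the assay and not a number. Compound 2 likewise gives only a limit, > 50 ug/mL. Compound 3 also sits at a limit, > 50 ug/mL. Within the data shown here, the one measured step, a step that the two limits leave unreadable from compound 2 to compound 3, is therefore unreadable in size; all three values share (the limit of > 50 ug/mL in this assay, at which 3 of the 3 values shown sit).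

Compound 4, `COc1nc(-c2ccccc2Cl)ccc1[C@@H](c1ccccc1)[C@@](O)(CCN(C)C)c1cccc2ccccc12`, differs from compound 1 by 2-chlorophenyl in place of 4-bromophenyl on an aromatic carbon. Among the measured compounds shown here, no measured step covers this change, and the three limits show no gradient, so in this assay the expected step that the limit leaves unreadable from compound 1 to compound 4 is none beyond the scatter. Compound 4 is estimated at 60 ug/mL, range 30 ug/mL to 120 ug/mL, most likely reported again as a limit only.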

Compound 4, half-maximal cytotoxic concentration: > 50 ug/mL
Compound 4: a limit, no number (the forecaster's own chance of this, stated with the estimate: 80%); the middle value does not contradict the limit.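

Compound 4 gives > 50 ug/mL, a limit and not a number, so compound 1 and compound 4 yield no readable step: the limit of > 50 ug/mL in this assay, at which 4 of the 4 values shown sit.

The compounds shown leave open where the tolerated concentration of any of them actually lies, and whether 2-chlorophenyl in place of 4-bromophenyl shifts it at all.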